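Fluorinated benzyl group carried over to the longer-chain coumarin

A few compounds are considered here, and "the series" means these few. Any claim that something is new, unique, unknown or untested is made for them only; others in the source may bear on it.

Compound 1 `C#CCN(CCCCOc1ccc2ccc(=O)oc2c1)Cc1ccccc1` is the reference point here. In an assay on isolated protein for inhibition of Amine oxidase [flavin-containing] B (Homo sapiens), read by fluorescence and Amplex Red, with stated times of 15 min and 20 min (on this read-out lower numbers stand for stronger inhibition and higher numbers for weaker inhibition), compound 1 gives 978 nM, the lowest of the three measured numbers. Compound 3 `C#CCN(CCCOc1ccc2ccc(=O)oc2c1)Cc1ccccc1` gives 3740 nM in this assay, and compound 2 `C#CCN(CCCOc1ccc2ccc(=O)oc2c1)Cc1ccc(F)c(F)c1` gives 4860 nM. Compound 1 and compound 3 share the coumarin and the propargyl-benzylamine end but differ in the linker; the difference between the two cores is not broken down here.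

The move from compound 3 to compound 2 is 3,4-difluorophenyl in place of phenyl on a saturated chain carbon bound to an amine nitrogen, and it produced a 1.3-fold higher number from compound 3 to compound 2 (0.11 log units; within the scatter), a step that stays within the usual scatter of repeated measurements.

Compound 4 `C#CCN(CCCCOc1ccc2ccc(=O)oc2c1)Cc1ccc(F)c(F)c1` has not yet been measured. It differs from compound 1 by 3,4-difluorophenyl in place of phenyl on a saturated chain carbon bound to an amine nitrogen, at the same place as in the measured pair, so it is the same change made on the core of compound 1. Because the measured pair gave a 1.3-fold higher number from compound 3 to compound 2 (0.11 log units; within the scatter), a comparably small step is expected for compound 4, namely a 1.3-fold higher number from compound 1 to compound 4 (0.11 log units; within the scatter). On that basis compound 4 is estimated at 1270 nM in this assay, with a plausible range from 600 nM to 2800 nM.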

Compound 4, half-maximal inhibitory concentration: 2370 nM
Beside the measured number, compound 4's estimate is 1.9-fold (0.27 log units) below it, within the range that was stated.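

The change from phenyl to 3,4-difluorophenyl on the core of compound 1 gives a 2.4-fold higher number from compound 1 to compound 4 (0.38 log units; beyond the scatter) in this assay, so here it goes with modestly weaker inhibition. Set beside the earlier step, the result gives no sign that the effect of this change depends on the core, and the two steps can be read as one small effect seen twice: the same change on two cores in this assay, a 1.3-fold higher number (0.11 log units; within the scatter) from compound 3 to compound 2 and a 2.4-fold higher number (0.38 log units; beyond the scatter) from compound 1 to compound 4, 1.9-fold (0.27 log units) apart, within the scatter of two such steps This does not show that the change has a fixed size or that it weakens inhibition on every core, since only one of the two steps lies beyond the scatter and only two cores are shown.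

The compounds shown leave open how a single fluorine or a chlorine on the phenyl ring would compare with the 3,4-difluorophenyl group. They also leave open whether the same change would behave alike on a longer chain than that of compound 1.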